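A few compounds are considered here, and "the series" means these few. Any claim that something is new, unique, unknown or untested is made for them only; others in the source may bear on it.

Working notes on the series. In a functional assay for inhibition, with Homo sapiens as the target (on this read-out higher numbers stand for weaker binding and lower numbers for tighter binding), compound 1 (`CC(C)(Oc1ccccc1)C1OCC(C/C=C\CCC(=O)O)C(c2cccnc2)O1`) gives 75.9 nM and compound 2 (`CC(C)(C1OCC(C/C=C\CCC(=O)O)C(c2cccnc2)O1)S(=O)(=O)c1ccccc1`) gives 3160 nM, the higher of the two numbers and so the weaker binding of the pair.

Compound 3 (`CC(C)(Cc1ccc(F)cc1)C1OCC(C/C=C\CCC(=O)O)C(c2cccnc2)O1`) changes the same place on the shared core: 4-fluorobenzyl in place of phenylsulfonyl on a saturated chain carbon bound to two saturated chain carbons and a saturated ring carbon. In short, 4-fluorobenzyl stands in place of phenylsulfonyl.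

For the measured compounds named here, only one measured step bears on this. It is the large step of a 42-fold higher number from compound 1 to compound 2 (1.62 log units; beyond the scatter), which brought phenylsulfonyl in place of phenoxy at that carbon. Going by the values given here, compound 3 removes phenylsulfonyl again, but it does not restore phenoxy, and no measurement yet shows how 4-fluorobenzyl compares with phenoxy. A large move towards lower numbers is therefore expected, with the number still somewhat higher than that of compound 1, which gives 75.9 nM.

The expected change in this assay is a 21-fold lower number from compound 2 to compound 3 (1.32 log units; beyond the scatter), beyond the scatter and in the direction of tighter binding. For compound 3 the estimated value is 150 nM, with an expected range of 40 nM to 600 nM.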

Compound 3, dissociation constant: 89.1 nM
The estimate for compound 3 lay 1.7-fold (0.23 log units) above the measured number, within the range that was stated.
By their numbers in this assay, from the lowest: compounds 1 and 3 (each within the scatter of the next); then compound 2.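

In this assay the change is large, a 35-fold lower number from compound 2 to compound 3 (1.55 log units; beyond the scatter), and it shows that the high number of compound 2 does not hold once phenylsulfonyl leaves this saturated chain carbon. The second new step, a 1.2-fold higher number from compound 1 to compound 3 (0.07 log units; within the scatter), lies within the scatter, so phenoxy and 4-fluorobenzyl cannot be told apart here, and of the three groups shown only phenylsulfonyl stands apart; since phenylsulfonyl and 4-fluorobenzyl each carry one six-membered aromatic ring of carbon only, that ring alone does not separate compound 2 from compound 3. Nothing measured independently speaks to what sets phenylsulfonyl apart from the other two groups.

The compounds shown leave open whether the fluorine of 4-fluorobenzyl matters at all, as plain benzyl does not stand among them for comparison. Also open, on these data alone, is how phenylthio, which would separate the sulfur atom from the two oxygens of phenylsulfonyl, would read at the same carbon, and how an amine, a carboxylic acid or a longer chain ending in phenyl would read there.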